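The source may report more compounds than this note shows. Statements on the series, on what has been measured and on what is new or still open speak of the compounds shown alone.

Three compounds sharing one core have gone into a functional assay on A-375 cells (Homo sapiens) for antiproliferative activity, read by CCK-8 assay, with a stated time of 72 h (a lower number here means a stronger inhibitor, a higher number a weaker inhibitor), so far. Compound 1 (`CCc1ccc(SCc2ccc(/C=C/C(=O)Nc3ccccc3N)cc2)cc1`) stands at "not determined" (no result reported) and so offers nothing to compare. Compound 2 (`COc1ccc(SCc2ccc(C(=O)Nc3ccccc3N)cc2)cc1`) gives 3010 nM and compound 3 (`Nc1ccccc1NC(=O)c1ccc(CSc2cccc(F)c2)cc1`) gives 3900 nM as its reading, which places these two level with each other within the scatter. Compound 3 therefore sits with compound 2, in the low micromolar part of the scale, and neither can be called the better of the pair.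

Compound 4 (`Nc1ccccc1NC(=O)c1ccc(CSCCc2ccccc2)cc1`) changes one thing in compound 3: on the sulfur, phenethyl stands in place of 3-fluorophenyl (phenethyl in place of 3-fluorophenyl on a sulfur). Among the measured compounds shown here, the one measured step at that sulfur, 3-fluorophenyl in place of 4-methoxyphenyl, was a 1.3-fold higher number from compound 2 to compound 3 (0.11 log units; within the scatter) and thus stayed small. For the measured compounds named here, that step gives only a weak guide here, since no measured compound carries phenethyl on the sulfur. Swapping one group for another at this place has so far left the number unmoved, so no shift beyond the scatter is expected in this assay and neither direction is favoured. The estimated change is a 1.0-fold higher number from compound 3 to compound 4 (0.01 log units; within the scatter) on this reasoning. Compound 4 is expected at about 4000 nM in this assay with an estimated range of 1300 nM to 12000 nM around that middle.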

Compound 4, half-maximal inhibitory concentration: 2860 nM
For compound 4 the middle estimate is 1.4-fold (0.15 log units) above the measured one; the range from low to high includes it.
By their numbers in this assay, from the lowest: compounds 4, 2 and 3 (each within the scatter of the next).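

In this assay, the sulfur now carries phenethyl rather than a phenyl group with a single substituent, and the comparison with 3-fluorophenyl gives a 1.4-fold lower number from compound 3 to compound 4 (0.13 log units; within the scatter), while the comparison with 4-methoxyphenyl gives a 1.1-fold lower number from compound 2 to compound 4 (0.02 log units; within the scatter). The earlier step exchanged only 3-fluorophenyl for 4-methoxyphenyl, whereas these two steps show that phenethyl, with 8 heavy atoms against the 7 of 3-fluorophenyl and carrying no fluorine, also leaves the number within the scatter, so compounds 2, 3 and 4 cannot be ranked by the group on this sulfur. No measured evidence accounts for this flat result, so it remains an observation about these three compounds and has no established explanation.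

The compounds shown leave open whether a group of a different kind on the sulfur, such as a chain ending in an amine or a carboxylic acid, would move the number beyond the scatter. They also leave open whether a longer chain than phenethyl would keep the number where compounds 2, 3 and 4 now stand.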